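Series notes: phenoxy in place of 3-methoxyphenyl

The compounds below may be only part of what the source reports. "The series", "measured", "known", "first", "only" and "open" are said of these compounds alone.

Compound 2 `COc1cccc(-c2ccc(S(=O)(=O)Nc3cc(N4C[C@@H](C)N[C@@H](C)C4)ccc3OC)cc2)c1` is the reference point for the next step. Among the compounds with values here, in a functional assay for agonist activity at growth hormone secretagogue receptor type 1 (Homo sapiens), read by FLIPR (a higher number here means that more compound is needed for the effect, a lower number that less compound is needed), compound 2 gives 2 nM, the lowest of the two numbers measured so far. The nearest is compound 1 `CCOc1ccc(N2C[C@@H](C)N[C@@H](C)C2)cc1NS(=O)(=O)c1ccc(-c2ccccn2)s1`, which in this assay gives 39.8 nM; the gap between the two is beyond the scatter. Compound 1 differs from compound 2 in more than one place, so no single step can be read from the pair; the two values only show that compound 2 sits well below compound 1.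

Compound 3 `COc1ccc(N2C[C@@H](C)N[C@@H](C)C2)cc1NS(=O)(=O)c1ccc(Oc2ccccc2)cc1` has not yet been measured in this assay. It keeps the core of compound 2 and changes one group: phenoxy in place of 3-methoxyphenyl on an aromatic carbon. Within the data shown here, no measured pair in the set isolates a change of this kind, so the step is judged without a precedent. The expected step is a 5.0-fold higher number from compound 2 to compound 3 (0.70 log units; beyond the scatter), an increase in the number that goes beyond the usual scatter but stays moderate. Compound 3 is therefore estimated at 10 nM, with a range from 3 nM to 40 nM.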

Compound 3, half-maximal effective concentration: 63.1 nM
Compound 3: the middle estimate sits 6.3-fold (0.80 log units) below what was measured; the whole stated range lies below it.
By their numbers in this assay, from the lowest: compound 2; then compounds 1 and 3 (each within the scatter of the next).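

Within the data shown here, the change from 3-methoxyphenyl to phenoxy, on an aromatic carbon para to a large group, provides the first step that can be read at a single place: in this assay the change gives a 32-fold higher number from compound 2 to compound 3 (1.50 log units; beyond the scatter) and this is a large step. This position is therefore not indifferent to the group it carries, even though the two groups are close in what can be counted: 8 heavy atoms against 7, one six-membered aromatic ring of carbon only in each, the same count of hydrogen-bond acceptors, no hydrogen-bond donors and no net charge. No measurement is available that bears on the cause of this step, so none is assigned here.

Still open, as far as these compounds go, is whether the step goes with the loss of the methoxy group or with the oxygen of phenoxy, and plain phenyl or 3-methoxyphenoxy at the same place would separate the two. Also open, from the compounds shown here alone, is how this position responds to groups of another kind, such as a piperidine, a carboxylic acid or a benzyloxy group.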